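A few compounds are considered here, and "the series" means these few. Any claim that something is new, unique, unknown or untested is made for them only; others in the source may bear on it.

Working notes on the series. Compound 1 `c1cncc(N2C[C@@H]3C[C@H]2CN3)c1` is one of two compounds with a number in an assay on a protein complex for agonist activity at Neuronal acetylcholine receptor; alpha4/beta2 (Homo sapiens); a higher number here means a weaker inhibitor, a lower number a stronger inhibitor; in this assay compound 1 gives 0.15 nM, the higher of the two. The other compound, compound 2 `Clc1ccc(N2CC3CC2CN3)cn1`, gives 0.018 nM in this assay, a lower number, and the gap between the two lies beyond the usual scatter. Going by the values given here, no single-change step between measured compounds exists, so nothing in the data shows what inverting the configuration does.

Compound 3 `c1cncc(N2C[C@H]3C[C@@H]2CN3)c1` is the next compound. The change from compound 1 is the two compounds have the same atoms and bonds and differ only in configuration as drawn: 2 of 2 stereo elements differ (all stereocentres are inverted: mirror images); a stereocentre at a saturated ring carbon is drawn S in compound 1 and R in compound 3; a stereocentre at a saturated ring carbon is drawn S in compound 1 and R in compound 3. Among the compounds with values here, with no measured step of this kind, only a guess is possible: a modest move toward a higher number is expected, one that may still lie within the scatter. Compound 3 is estimated at 0.4 nM in this assay, within 0.08 nM to 3 nM, meaning an expected step of a 2.7-fold higher number from compound 1 to compound 3 (0.43 log units; beyond the scatter).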

Compound 3, inhibition constant: 0.02 nM
The estimate for compound 3 lay 20-fold (1.30 log units) above the measured number, and the stated range ends above it.
By their numbers in this assay, from the lowest: compounds 2 and 3 (each within the scatter of the next); then compound 1.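

In this assay, going by these compounds alone, inverting both stereocentres gives a 7.5-fold lower number from compound 1 to compound 3 (0.88 log units; beyond the scatter) and this is the first single-change step. Configuration alone is thus enough to move the number beyond the scatter, and the mirror image drawn as compound 3 lies on the lower side. The step can be assigned to configuration and to nothing else because no atom or bond changes: the fact that compounds 1 and 3 differ only in the configuration as drawn.

Both stereocentres invert together, so the share of each cannot be told, and compound 2 is drawn without configuration, so the same step cannot be read for it. On these data alone, whether the preference for the configuration of compound 3 holds with a fluorine or a methoxy group on the shared core also stays open.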